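Propyl to isopentyl: working notes on cytotoxicity

The source may hold more compounds than are shown below. What is called first, only, known or untested is meant among the compounds shown, and "the series" means these compounds.

The series is read here in an ADME assay on J774.A1 cells (Mus musculus) for cytotoxicity, read by MTT assay, with a stated time of 48 h; a higher number here means that more compound is tolerated, a lower number that less compound is tolerated. Compound 1 `COc1ccc(CNC(=O)c2c([N+](=O)[O-])noc2-c2ccc([N+](=O)[O-])cc2)cc1OC` offers no help, since its entry reads "not determined" (no result reported). Compound 2 `CCCNC(=O)c1c([N+](=O)[O-])noc1-c1ccc([N+](=O)[O-])cc1`, with its propyl chain on the amide, gives 76200 nM. Among the measured compounds shown here, that is the only number available, so it cannot yet be ranked against anything else.

The next compound to be tested is compound 3 `CC(C)CCNC(=O)c1c([N+](=O)[O-])noc1-c1ccc([N+](=O)[O-])cc1`. Its change is isopropyl in place of methyl on a saturated chain carbon, two bonds along the chain from an amide-type nitrogen. Read one bond further out, this is propyl to isopentyl, and the shared core stays untouched.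

For the measured compounds named here, no pair of measured compounds shows what a change of this kind does in this assay, so the expectation is anchored only on compound 2 at 76200 nM. A modest step toward less compound tolerated is expected, not far beyond the usual scatter and possibly within it. The expected step is a 1.5-fold lower number from compound 2 to compound 3 (0.17 log units; within the scatter). For compound 3 the estimated value is 52000 nM, with an expected range of 20000 nM to 120000 nM.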

Compound 3, half-maximal cytotoxic concentration: 67000 nM
Compound 3: middle estimate off by 1.3-fold (0.11 log units), on the low side, within the range that was stated.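

Among the compounds shown here, compound 3 gives the first step at this position: in this assay, isopropyl in place of methyl on a saturated chain carbon, two bonds along the chain from an amide-type nitrogen, gives a 1.1-fold lower number from compound 2 to compound 3 (0.06 log units; within the scatter), so on this pair the tolerated concentration does not separate the propyl amide from the isopentyl amide. The earlier entries could not show this, since they offered a single number and no comparison; the amide chain can now be read as a place where this particular swap leaves the cell read-out within repeat variation, although one pair sets no trend for chain length or branching. No measurement on these compounds accounts for the result.

From the compounds shown here alone, whether a longer chain such as octyl, or a chain ending in an amine or a carboxylic acid, would also stay level with compound 2 in this assay remains open. Also open, going by these compounds, is whether an unbranched pentyl chain would read like the isopentyl chain of compound 3, so chain length and branching cannot yet be told apart at this position.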